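Compound 3 to compound 4: a ring exchange

The source may report more compounds than this note shows. Statements on the series, on what has been measured and on what is new or still open speak of the compounds shown alone.

In an ADME assay on microsomes from liver (Rattus norvegicus) for metabolic stability (on this read-out lower numbers stand for a shorter-lived compound and higher numbers for a longer-lived compound), compound 3 (`CC(C)C(c1ccc(-c2ccc3cccc(F)c3c2)[nH]c1=O)C1NC(=O)NC1=O`) gives 0.145 h, the lower of the two actual numbers in the series. The nearest number belongs to compound 1 (`CC(C)C(/C=C1\NC(=O)NC1=O)c1ccc(-c2ccc3cccc(F)c3c2)[nH]c1=O`), at 1.46 h. For compound 2 (`CC(C)C(CC1C(=O)NC(=O)N1C)c1ccc(-c2ccc3cccc(F)c3c2)[nH]c1=O`) the result is only a limit, < 0.0667 h.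

Compound 4 (`CC(C)C(c1ccc(-c2ccc3cccc(F)c3c2)[nH]c1=O)C1SC(=O)NC1=O`) carries 2,4-dioxo-1,3-thiazolidin-5-yl in place of 2,5-dioxoimidazolidin-4-yl on a saturated chain carbon bound to an aromatic carbon and a saturated chain carbon.

Among the measured compounds shown here, three measured steps bear on this place: a 10-fold lower number from compound 1 to compound 3 (1.00 log units; beyond the scatter), an at least 21-fold lower number from compound 1 to compound 2 (1.34 log units; beyond the scatter) and an at least 2.1-fold higher number from compound 2 to compound 3 (0.33 log units; beyond the scatter). All lie beyond the scatter, so values in this assay can move widely here. None of them makes the ring exchange found in compound 4, however, and they give no direction for it. No step beyond the scatter is therefore assumed, though a wide range is kept. The expected change is a 1.0-fold higher number from compound 3 to compound 4 (0.01 log units; within the scatter). For compound 4 the estimated half-life is 0.15 h, with an expected range of 0.07 h to 0.45 h.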

Compound 4, half-life: 0.76 h
Beside the measured number, compound 4's estimate is 5.1-fold (0.70 log units) below it; the measured number lies above the stated range.
By their numbers in this assay, from the lowest: compound 3; then compounds 4 and 1 (each within the scatter of the next). At a limit, below all of these: compound 2.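

In this assay, the step of a 5.2-fold higher number from compound 3 to compound 4 (0.72 log units; beyond the scatter) shows that this position responds to 2,4-dioxo-1,3-thiazolidin-5-yl in place of 2,5-dioxoimidazolidin-4-yl at an unchanged heavy-atom count, whereas every earlier step changed the size of the group. The step of a 1.9-fold lower number from compound 1 to compound 4 (0.28 log units; within the scatter) leaves compound 1 and compound 4 unseparated, although their groups differ in size and make-up. The step of an at least 11-fold higher number from compound 2 to compound 4 (1.05 log units; beyond the scatter) is a bound only, its starting number being a limit: the limit of < 0.0667 h in this assay, at which 1 of the 4 values shown sits.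

The compounds shown do not separate the ring sulfur from the altered hydrogen-bond donor and acceptor counts as the source of the step to compound 4. Also open, on these data alone, is how a 2,4-dioxo-1,3-oxazolidin-5-yl group, with oxygen in place of the ring sulfur, would read at this position.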